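The source may report more compounds than this note shows. Statements on the series, on what has been measured and on what is new or still open speak of the compounds shown alone.

Measured compounds in a functional assay on HEK293 cells for antagonist activity at transient receptor potential cation channel subfamily M member 8 (Rattus norvegicus), read by calcium flux; on this read-out lower numbers stand for stronger inhibition and higher numbers for weaker inhibition:

- compound 1 `Cc1ccc(C(=O)N[C@@H]2C[C@H](C)CC[C@H]2C(C)C)cc1`: 2500 nM
- compound 2 `CC(C)[C@@H]1CC[C@@H](C)C[C@H]1NC(=O)c1ccc(-c2ccccc2)cc1`: 50 nM

Going by the values given here, compound 2 stands at the lowest number of the two measured in this assay; the only neighbour is compound 1, whose value is the higher one. Among the compounds with values here, the single measured step, a 50-fold lower number from compound 1 to compound 2 (1.70 log units; beyond the scatter), was phenyl in place of methyl on an aromatic carbon, and it is large and well beyond the scatter.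

Compound 3 `CC(C)[C@@H]1CC[C@@H](C)C[C@H]1NC(=O)c1ccc(Cl)cc1` differs from compound 2 by chloro in place of phenyl on an aromatic carbon, on an aromatic carbon of a six-membered aromatic ring of carbon only, para to a large group. Within the data shown here, no measured pair covers phenyl against chloro directly, so the only bearing step is a 50-fold lower number from compound 1 to compound 2 (1.70 log units; beyond the scatter), which shows that removing the phenyl in favour of a one-heavy-atom group costs a large amount in this assay. Chloro, like methyl, is a single heavy atom, so a step of similar direction and size is expected, though not necessarily the full amount. The estimate for compound 3 is therefore 1000 nM, range 250 nM to 4000 nM, meaning an expected step of a 20-fold higher number from compound 2 to compound 3 (1.30 log units; beyond the scatter).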

Compound 3, half-maximal inhibitory concentration: 1600 nM
Estimate against measurement, compound 3: 1.6-fold (0.20 log units) below, within the range that was stated.
By their numbers in this assay, from the lowest: compound 2; then compounds 3 and 1 (each within the scatter of the next).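

Replacing phenyl with chloro on this aromatic carbon, para to a large group, gives in this assay a 32-fold higher number from compound 2 to compound 3 (1.51 log units; beyond the scatter), so the advantage of phenyl now stands against two different one-heavy-atom groups and no longer rests on methyl alone. Chloro and methyl at this position cannot be told apart, since a 1.6-fold lower number from compound 1 to compound 3 (0.19 log units; within the scatter) lies within the scatter, and compound 2 remains the strongest inhibitor of the three, with both of its steps printed as beyond the scatter. The values describe the size of the change only, and no measurement shown here speaks to its cause.

Still open, as far as these compounds go, is whether the gain requires an aromatic ring at this place or comes with any group larger than a single heavy atom, a question that a cyclohexyl group or a butyl chain would address. Also open, from the compounds shown here alone, is how far the phenyl itself can be changed, for example by a nitrile or methoxy group on it or by a pyridine ring in its place, while keeping a number close to that of compound 2 at 50 nM in this assay.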